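Nitro added beside the methoxy of compound 1

This account rests on a few compounds, and the source may have more. Where it says the series, first, only, none or still open, it means among the compounds named here.

Working notes on a pair of benzyl imidazole-thiones and one untested variant. In an assay on isolated protein for inhibition of Dopamine beta-hydroxylase (Rattus norvegicus) (a higher number here means a weaker inhibitor, a lower number a stronger inhibitor), compound 1 `COc1ccc(Cn2cc[nH]c2=S)cc1` gives 204000 nM, the highest of the two numbers recorded so far. Its nearest neighbour, compound 2 `Oc1c(F)cc(Cn2cc[nH]c2=S)cc1F`, gives 74.1 nM in this assay, a gap that lies well beyond the usual scatter. Going by the values given here, compound 2 differs from compound 1 at more than one place, so no single step between them can be drawn; the two values only show how far apart the pair lies.

Compound 3 `COc1ccc(Cn2cc[nH]c2=S)cc1[N+](=O)[O-]` carries one change relative to compound 1: nitro in place of hydrogen on an aromatic carbon. Among the compounds with values here, no measured step of this kind exists, so the direction cannot be read from the data. A step from compound 1 to compound 3 that stays small is expected, possibly toward a lower number, but not clearly beyond the scatter; the expected step is a 1.7-fold lower number from compound 1 to compound 3 (0.23 log units; within the scatter). For compound 3 the expected value in this assay is 120000 nM, with a range from 25000 nM to 500000 nM.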

Compound 3, half-maximal inhibitory concentration: 355000 nM
The estimate for compound 3 lay 3.0-fold (0.47 log units) below the measured number; measured number inside the range.
By their numbers in this assay, from the lowest: compound 2; then compounds 1 and 3 (each within the scatter of the next).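

In this assay, going by these compounds alone, the replacement of hydrogen by nitro on an aromatic carbon, ortho to a methoxy group, gives the first single-change step (a 1.7-fold higher number from compound 1 to compound 3 (0.24 log units; within the scatter)). This step stays within the scatter, so the assay does not separate compound 1 from compound 3, and this position carries a nitro group without a difference that can be told from repeat measurement. The measurements shown offer no information that would explain this outcome.

Within the data shown here, the single step tests only one group at one position, so it remains open whether an amine or a carboxylic acid on the same aromatic carbon would give a step beyond the scatter. As far as these compounds go, it also remains open whether nitro would give a similarly small step without the methoxy group, or on the more heavily substituted ring of compound 2, where the phenol and the two fluorines might change the picture.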